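The source may hold more compounds than are shown below. What is called first, only, known or untested is meant among the compounds shown, and "the series" means these compounds.

Measured so far:
compound 1 `C=CCc1cc(OC)c(OC(C)C(OC2CCCCC2)c2ccc(O)c(OC)c2)c(OC)c1` gives 54 nM
compound 2 `C=CCc1cc(OC)c(O[C@H](C)[C@@H](OCC)c2ccc(O)c(OC)c2)c(OC)c1` gives 1150 nM
compound 3 `C=CCc1cc(OC)c(OC(C)C(OCC(C)C)c2ccc(O)c(OC)c2)c(OC)c1` gives 138 nM

In an assay on HEK293 cells for agonist activity at transient receptor potential cation channel subfamily M member 8 (Homo sapiens), read by fluorescence and calcium flux, with a stated time of 5 min (a higher number here means that more compound is needed for the effect, a lower number that less compound is needed), compound 3 stands second of the three numbers: its nearest neighbour is compound 1, and compound 2 lies furthest from it. Compound 4 `C=CCc1cc(OC)c(OC(C)C(OCC)c2ccc(O)c(OC)c2)c(OC)c1` is not yet measured; it differs from compound 3 in one place: methyl in place of isopropyl on a saturated chain carbon bound to an oxygen on a saturated carbon. Going by the values given here, one measured step bears on it, the replacement of cyclohexyl by isobutyl, which gave a 2.6-fold higher number from compound 1 to compound 3 (0.41 log units; beyond the scatter); the shorter the group on this oxygen, the higher the number ran, and compound 2, which also carries ethyl here, gives 1150 nM. A further shortening is therefore expected to raise the number again, so compound 4 is estimated at 600 nM, range 200 nM to 2000 nM, the expected step being a 4.3-fold higher number from compound 3 to compound 4 (0.64 log units; beyond the scatter).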

Compound 4, half-maximal effective concentration: 332 nM
Compound 4: middle estimate off by 1.8-fold (0.26 log units), on the high side; the range from low to high includes it.
By their numbers in this assay, from the lowest: compound 1; then compound 3; then compound 4; then compound 2.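

In this assay, the ethoxy compound sits higher again, with a 2.4-fold higher number from compound 3 to compound 4 (0.38 log units; beyond the scatter) and, over the whole change, a 6.1-fold higher number from compound 1 to compound 4 (0.79 log units; beyond the scatter) on this oxygen. Cyclohexyl, isobutyl and ethyl thus fall in one order among the three compounds drawn without configuration, and compound 2 stands outside that comparison. The same atoms and bonds give a 3.5-fold lower number from compound 2 to compound 4 (0.54 log units; beyond the scatter) as a gap that cannot be read as an effect of configuration: the fact that one of compounds 2 and 4 is drawn with a defined configuration and the other without, at the place where they differ.

Open, from the compounds shown here alone, is whether this order extends to a benzyl group, a longer chain or a chain carrying an amine. Also open, going by these compounds, is how the separate stereoisomers of compound 4 compare.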